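The source may hold more compounds than are shown below. What is called first, only, known or untested is meant among the compounds shown, and "the series" means these compounds.

Compound 1 `Cc1cc(=O)c2c(O)cc(OCC3CO3)cc2o1`: 143000 nM
Compound 2 `Cc1cc(=O)c2c(O)cc(OC[C@H]3CO3)cc2o1`: 9740 nM
Compound 3 `Cc1cc(=O)c2c(OC[C@H]3CO3)cc(OC[C@H]3CO3)cc2o1`: 7860 nM

In a functional assay on K562 cells (Homo sapiens) for antiproliferative activity, with a stated time of 48 h (a lower number here means a stronger inhibitor, a higher number a weaker inhibitor), compound 2 gives 9740 nM, level with compound 3 within the scatter and far lower than compound 1. Compound 4 `Cc1cc(=O)c2c(O)cc(OC[C@@H]3CO3)cc2o1` is the mirror case at the one stereocentre: the two compounds have the same atoms and bonds and differ only in configuration as drawn: 1 of 1 stereo elements differ; a stereocentre at a saturated ring carbon is drawn R in compound 2 and S in compound 4. The step that bears most directly on this is a 15-fold lower number from compound 1 to compound 2 (1.17 log units; beyond the scatter), which goes with the fact that one of compounds 1 and 2 is drawn with a defined configuration and the other without, at the place where they differ. The other step, a 1.2-fold lower number from compound 2 to compound 3 (0.09 log units; within the scatter), concerns a different place and adds little. Since drawing the R configuration accompanied the lower number in the first of these steps, S is expected to be the weaker form, though by an uncertain margin. Expected in this assay is a 3.1-fold higher number from compound 2 to compound 4 (0.49 log units; beyond the scatter), beyond the scatter. For compound 4 the estimated value is 30000 nM, with an expected range of 8000 nM to 140000 nM.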

Compound 4, half-maximal inhibitory concentration: 8030 nM
For compound 4 the middle estimate is 3.7-fold (0.57 log units) above the measured one; measured number inside the range.
By their numbers in this assay, from the lowest: compounds 3, 4 and 2 (each within the scatter of the next); then compound 1.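

In this assay, the configuration at the saturated ring carbon makes no readable difference, with a 1.2-fold lower number from compound 2 to compound 4 (0.08 log units; within the scatter): the fact that compounds 2 and 4 differ only in the configuration as drawn. The large gap to compound 1 recurs with the S form, at an 18-fold lower number from compound 1 to compound 4 (1.25 log units; beyond the scatter), so it follows neither configuration in particular but separates both defined drawings from the undefined one: the fact that one of compounds 1 and 4 is drawn with a defined configuration and the other without, at the place where they differ. The R configuration therefore holds no advantage over S in this series. These data do not explain the high number of compound 1.

On these data alone, whether the oxirane ring itself is needed remains open, as a 2,3-dihydroxypropyl chain or an amine-bearing propyl chain on the same oxygen would show. Also open, as far as these compounds go, is whether the stereocentre stays equally silent in the compound 3 pattern, with both oxygens carrying the S form of (oxiran-2-yl)methyl.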